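The compounds below may be only part of what the source reports. "The series", "measured", "known", "first", "only" and "open" are said of these compounds alone.

Measured in an ADME assay on HEK293 cells (Homo sapiens) for cytotoxicity, with a stated time of 6 h; a lower number here means that less compound is tolerated, a higher number that more compound is tolerated:
Compound 1 `CCCCNc1nc(N)nc2cccc(Cl)c12`: 100 nM
Compound 2 `CCCCNc1nc(N)nc2cccc(C)c12`: > 25000 nM (a limit)
Compound 3 `CCCCNc1nc(N)nc2cccc(OC)c12`: > 25000 nM (a limit)

Compound 3 gives no number, only the limit > 25000 nM. Compound 4 `CCCCNc1nc(N)nc2cccc(CC3CCCC3)c12` carries cyclopentylmethyl in place of methoxy on an aromatic carbon. Within the data shown here, no measured step brings in this group, but two steps away from chloro bear on it: an at least 250-fold higher number from compound 1 to compound 2 (2.39 log units; beyond the scatter), and an at least 250-fold higher number from compound 1 to compound 3 (2.39 log units; beyond the scatter). The step that the two limits leave unreadable from compound 2 to compound 3 adds nothing readable. Compound 4 also lacks chloro, so it is expected to remain far from compound 1 at 100 nM. Only a modest fall from the limit of compound 3 is expected. The expected change is an at least 1.6-fold lower number from compound 3 to compound 4 (0.22 log units; that floor lies within the scatter). For compound 4 the estimated value is 15000 nM, within an expected range of 3000 nM to 40000 nM.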

Compound 4, half-maximal cytotoxic concentration: > 25000 nM
Compound 4: only a limit was reported; the forecaster's own chance of this, stated with the estimate: 60%; middle value at least 1.6-fold (0.22 log units) from the limit.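

In this assay compound 4 also gives only a limit, > 25000 nM. Cyclopentylmethyl, with its five-membered non-aromatic ring, shows an at least 250-fold higher number from compound 1 to compound 4 (2.39 log units; beyond the scatter), so the distance from compound 1 seen with methyl and methoxy also holds for this group of six heavy atoms. The steps among compound 2, compound 3 and compound 4 cannot be read: the limit of > 25000 nM in this assay, at which 3 of the 4 values shown sit.

From the compounds shown here alone, how far these three compounds lie beyond that limit stays open, so no order among them can be given. Going by these compounds, whether bromo or an amine at this place would give a value near that of compound 1 also stays open.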